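A few compounds are considered here, and "the series" means these few. Any claim that something is new, unique, unknown or untested is made for them only; others in the source may bear on it.

Measured in a toxicity assay on MDCK cells (Canis lupus familiaris) for cytotoxicity, read by CCK-8 assay, with a stated time of 48 h; a higher number here means that more compound is tolerated, a lower number that less compound is tolerated:
Compound 1 `CCCOc1ccc(C(=O)NNc2c(Br)cccc2Br)cc1`: > 100000 nM, a limit.
Compound 2 `O=C(NNc1c(Br)cccc1Br)c1ccc(OCC(F)(F)F)cc1`: > 100000 nM, a limit.
Compound 3 `O=C(NNc1c(Br)cccc1Br)c1ccc(Br)cc1`: > 100000 nM, a limit.

Compound 3 gives no number, and it shares this position with the other two compounds: the limit of > 100000 nM in this assay, at which 3 of the 3 values shown sit. Compound 4 `O=C(O)c1ccc(C(=O)NNc2c(Br)cccc2Br)cc1` has carboxy in place of bromo on an aromatic carbon, para to a large group (carboxy in place of bromo on an aromatic carbon). Two measured changes at this place bear on it: a step that the two limits leave unreadable from compound 1 to compound 3 and a step that the two limits leave unreadable from compound 2 to compound 3. Neither has a readable size, so they support no particular size or direction of change in this assay. The expected change is a step that the limit leaves unreadable from compound 3 to compound 4, and it is only an estimate. Compound 4 is likely to be reported as a limit too. For compound 4 the estimated value is 150000 nM, with an expected range of 60000 nM to 400000 nM.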

Compound 4, half-maximal cytotoxic concentration: > 100000 nM
Compound 4: only a limit was reported (the forecaster's own chance of this, stated with the estimate: 90%); the middle value does not contradict the limit.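

No step can be read between compound 4 and compound 1, compound 2 or compound 3 in this assay, as all are limits: the limit of > 100000 nM in this assay, at which 4 of the 4 values shown sit. The compounds shown leave open whether exchanging these groups changes cytotoxicity at all.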